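Moving a fluorine around the ring on a piperazine

The source may hold more compounds than are shown below. What is called first, only, known or untested is meant among the compounds shown, and "the series" means these compounds.

Measured compounds:
compound 1, `CC1(c2ccccc2)CC(=O)N(CC(=O)N2CCOCC2)C1=O`, gives 300 mg/kg
compound 2, `CC1(c2ccccc2)CC(=O)N(CC(=O)N2CCN(c3ccccc3)CC2)C1=O`, gives 300 mg/kg
compound 3, `CC1(c2ccccc2)CC(=O)N(CC(=O)N2CCN(c3ccc(F)cc3)CC2)C1=O`, gives "not active" (no number reported)

All three share the same core and were tested in a functional assay on the whole organism (strain CD-1) with Mus musculus as the target, with a stated time of 2 h; a higher number here means that more compound is needed for the effect, a lower number that less compound is needed. Compound 1 and compound 2 each reach the effect at the same dose. For compound 3 only the outcome "not active" was reported, so no number exists for it, and compound 3 cannot be placed on a scale against the other two beyond saying that no effective dose was found.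

Compound 4, `CC1(c2ccccc2)CC(=O)N(CC(=O)N2CCN(c3ccccc3F)CC2)C1=O`, is the next compound. It differs from compound 3 in one place: 2-fluorophenyl in place of 4-fluorophenyl on an amine nitrogen in a ring. Among the measured compounds shown here, since compound 3 gave no number, no step between measured compounds is available for this kind of change. From compound 1 and compound 2 alone, which share the same dose, the expectation is that a small change on this ring will at best return a dose near theirs, with a real chance that, like compound 3, nothing is found. Compound 4 is therefore expected to give about 300 mg/kg, within a range from 100 mg/kg to 1000 mg/kg.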

Compound 4, minimum effective dose: 300 mg/kg
Beside the measured number, compound 4's estimate shows no gap at the digits printed; low and high end bracket the measured number.
By their numbers in this assay, from the lowest: compounds 1, 2 and 4 (each within the scatter of the next).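

In this assay, fluoro in place of hydrogen on an aromatic carbon gives no change at the digits printed from compound 2 to compound 4 (within the scatter), so a fluorine on the phenyl group can be present with an effective dose still found. Among the compounds shown here, compound 3 and compound 4 hold the same atoms, yet 4-fluorophenyl came with the outcome "not active" and 2-fluorophenyl with a measured dose, which shows that the outcome can differ with where the fluorine sits on the ring, although no step involving compound 3 can be read without a number for it. Nothing measured here explains why these two outcomes differ.

As far as these compounds go, it remains open whether a chlorine or a methoxy group in place of the fluorine would also give an effective dose. Equally open, from the compounds shown here alone, is what a pyridine ring in place of the phenyl ring on the piperazine nitrogen would do.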